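The source may hold more compounds than are shown below. What is called first, only, known or untested is meant among the compounds shown, and "the series" means these compounds.

Measured in a functional assay on A-375 cells (Homo sapiens) for antiproliferative activity, read by sulforhodamine B assay, with a stated time of 96 h; a lower number here means a stronger inhibitor, a higher number a weaker inhibitor:

- Compound 1 `C/C(=C\CC/C(C)=C/CC[C@@H]1[C@@]2(C)CCC(=O)C(C)(C)[C@@H]2CC[C@@]1(C)O)CC/C=C(\C)C(=O)OCCBr`: > 30000 nM
- Compound 2 `C/C(=C\CC/C(C)=C/CC[C@@H]1[C@@]2(C)CCC(=O)C(C)(C)[C@@H]2CC[C@@]1(C)O)CC/C=C(\C)C(=O)OCCCBr`: 11800 nM
- Compound 3 `C/C(=C\CC/C(C)=C/CC[C@@H]1[C@@]2(C)CCC(=O)C(C)(C)[C@@H]2CC[C@@]1(C)O)CC/C=C(\C)C(=O)OCCCCBr`: not yet measured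

The entry for compound 1, > 30000 nM, is a limit of the assay and not a number. Going by the values given here, that leaves compound 2, at 11800 nM, with the only true number in this assay. Compound 2 can be placed only against the limit of compound 1.

The move to compound 3 is bromomethyl in place of bromo on a saturated chain carbon, three bonds along the chain from an oxygen next to a carbonyl group. The same difference reads 3-bromopropyl to 4-bromobutyl.

One measured step is of the same kind, made two bonds along the chain from that oxygen. From the compounds shown here alone, it is an at least 2.5-fold lower number from compound 1 to compound 2 (0.40 log units; beyond the scatter), which lies beyond the scatter, and its full size stays open since it starts from a limit. A single step sets no trend, so only a small further fall is expected in this assay, possibly not beyond the scatter. The expected step is a 1.7-fold lower number from compound 2 to compound 3 (0.23 log units; within the scatter). The estimate for compound 3 is 7000 nM, with an expected range of 2800 nM to 18000 nM.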

Compound 3, half-maximal inhibitory concentration: 14500 nM
Compound 3: middle estimate off by 2.1-fold (0.32 log units), on the low side, within the range that was stated.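

In this assay, going by these compounds alone, extending the chain from 3-bromopropyl to 4-bromobutyl gives a 1.2-fold higher number from compound 2 to compound 3 (0.09 log units; within the scatter), so the one earlier step of this kind is not repeated at this position. Measured from the other end of the series, the 4-bromobutyl chain still gives an at least 2.0-fold lower number from compound 1 to compound 3 (0.31 log units; beyond the scatter), which means that both longer chains stand clear of 2-bromoethyl, with no further gain from the last added carbon. The full size of the steps from compound 1 cannot be read because the entry for that compound is a limit and not a number: the limit of > 30000 nM in this assay, at which 1 of the 3 values shown sits.

The compounds shown leave open whether a longer chain than 4-bromobutyl would stay level with compound 2 and compound 3 or move beyond the scatter. They also leave open how much of the activity depends on the terminal bromine, which could be tested by ending the same chain in chlorine, an amine or a carboxylic acid.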